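The source may hold more compounds than are shown below. What is called first, only, known or untested is meant among the compounds shown, and "the series" means these compounds.

The shared core appears in compound 2 `CC(C)=CCCC1=CC[C@@H](C(=O)NO)[C@H](c2ccccc2)C1`, whose amide nitrogen carries a hydroxy group; in an assay on isolated protein for inhibition of Apoptosis regulator Bcl-2 (Homo sapiens), read by fluorescence polarization, with stated times of 5 min and 10 min (a higher number here means a weaker inhibitor, a lower number a stronger inhibitor), compound 2 gives 700 nM. Compound 3 `CC(C)=CCCC1=CC[C@@H](C(=O)NCCC(=O)O)[C@H](c2ccccc2)C1` carries a 2-carboxyethyl group on that nitrogen. In this assay compound 3 gives only a limit, > 23000 nM. Compound 1 `CC(C)=CCCC1=CC[C@H](C(N)=O)[C@@H](c2ccccc2)C1`, a primary amide with the opposite arrangement at both ring carbons, also gives only a limit in this assay, > 23000 nM. The step of an at least 32-fold higher number from compound 2 to compound 3 (1.51 log units; beyond the scatter) is large, so compound 3 sits at the edge of what this assay can report (the limit of > 23000 nM in this assay, at which 2 of the 3 values shown sit). Compound 4 `CC(C)=CCCC1=CC[C@@H](C(N)=O)[C@H](c2ccccc2)C1` differs from compound 3 by hydrogen in place of 2-carboxyethyl on an amide-type nitrogen. Among the measured compounds shown here, no measured step covers this change directly. The step of an at least 1.1-fold lower number from compound 3 to compound 4 (0.06 log units; that floor lies within the scatter) is expected to stay within the scatter. Compound 4 is expected to give 20000 nM in this assay, between 3000 nM and 60000 nM.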

Compound 4, inhibition constant: > 23000 nM
Compound 4 was reported as a limit (the forecaster's own chance of this, stated with the estimate: 65%); middle value at least 1.1-fold (0.06 log units) from the limit.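

Taking the hydroxy group off the amide-type nitrogen, with no chain put in its place, already gives a large step (an at least 32-fold higher number from compound 2 to compound 4 (1.51 log units; beyond the scatter)), and it ends at a limit of this assay. Reaching that limit therefore does not require the 2-carboxyethyl group of compound 3. The steps from compound 3 to compound 4 and from compound 1 to compound 4 cannot be read, as each joins two limits: the limit of > 23000 nM in this assay, at which 3 of the 4 values shown sit.

Going by these compounds, whether a methoxy or an amino group on that nitrogen would keep any of the binding of compound 2 stays open. Any preference between the two ring arrangements also stays hidden among the primary amides: the fact that compounds 1 and 4 differ only in the configuration as drawn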